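A few compounds are considered here, and "the series" means these few. Any claim that something is new, unique, unknown or untested is made for them only; others in the source may bear on it.

In a functional assay on ileum (strain Hartley) for agonist activity at 5-hydroxytryptamine receptor 3A (Cavia porcellus) (a lower number here means a less potent compound, a higher number a more potent compound, by a factor of ten per unit of this negative logarithm), compound 2 `CCOC(=O)c1ccc2oc(N3CCN(C)CC3)nc2c1` gives only a limit, < 4. Compound 1 `CC(C)c1cccc2nc(N3CCN(C)CC3)oc12` likewise gives only a limit in this assay, < 4. Among the measured compounds shown here, both measurements sit at the limit of < 4 in this assay, at which 2 of the 2 values shown sit, so no measured step between compounds exists here. Compound 3 `CN1CCN(c2nc3cc(Br)ccc3o2)CC1` keeps the shared core and differs from compound 2 by bromo in place of ethoxycarbonyl on an aromatic carbon. With both measured compounds at the limit of < 4 in this assay, at which 2 of the 2 values shown sit, the expected step of a number no lower from compound 2 to compound 3 (the limit leaves the size open) is none beyond the scatter. Compound 3 is therefore estimated at 4 in this assay, with a range from 3.5 to 4.7, and a further limit rather than a number remains the likelier outcome.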

Compound 3, negative logarithm of the half-maximal effective concentration: 6.21
Beside the measured number, compound 3's estimate is 2.21 log units below it; the measured number lies above the stated range.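

Bromo in place of ethoxycarbonyl on this aromatic carbon gives, in this assay, a number at least 2.21 log units higher from compound 2 to compound 3 (beyond the scatter). This is the first change shown to lift a compound off the limit, and it shows that the shared core can give a readable number with the right group at this position: the limit of < 4 in this assay, at which 2 of the 3 values shown sit. Compound 2 gives only a limit, < 4, so the full size of the step stays open.

The compounds shown leave open whether chloro, methyl or an amine on this carbon would serve as well as bromo. They also leave open whether bromo would have the same effect on the other aromatic carbons of the shared core.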